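The source may report more compounds than this note shows. Statements on the series, on what has been measured and on what is new or still open speak of the compounds shown alone.

Measured in a functional assay on MDA-MB-231 cells (Homo sapiens) for antiproliferative activity, read by MTT assay, with a stated time of 48 h; on this read-out lower numbers stand for stronger inhibition and higher numbers for weaker inhibition:
- compound 1 `CN1CCN(c2ccc(-c3cc4c(N5CCN(S(=O)(=O)N6CCCCC6)CC5)ncnc4s3)cc2)CC1`: 8130 nM
- compound 2 `CN1CCN(c2ccc(-c3cc4c(N5CCN(C(=O)Nc6ccccc6)CC5)ncnc4s3)cc2)CC1`: 7590 nM

For the measured compounds named here, only these two numbers are available, and the single step joining them is small: a 1.1-fold lower number from compound 1 to compound 2 (0.03 log units; within the scatter). Going by the values given here, compound 2 therefore stands level with the only other measured compound, within the scatter.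

Compound 3 `CN1CCN(c2ccc(-c3cc4c(N5CCN(C(=O)Nc6ccc(C#N)cc6)CC5)ncnc4s3)cc2)CC1` keeps all of compound 2 except for cyano in place of hydrogen on an aromatic carbon, para to a large group, which turns phenylcarbamoyl into (4-cyanophenyl)carbamoyl: cyano in place of hydrogen on an aromatic carbon. Among the compounds with values here, no measured step adds cyano or any other group to this ring, so the data give no direct guide to this change. The nearest evidence is the exchange of the whole group on the same ring nitrogen, which moved the number by no more than the scatter, and the new change is far smaller in extent. No direction can be read from this, and no step beyond the scatter is expected in this assay. The expected step is a 1.2-fold lower number from compound 2 to compound 3 (0.07 log units; within the scatter). In this assay compound 3 is estimated at 6500 nM, with an expected range of 2500 nM to 15000 nM.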

Compound 3, half-maximal inhibitory concentration: 3930 nM
The estimate for compound 3 lay 1.7-fold (0.22 log units) above the measured number; measured number inside the range.
By their numbers in this assay, from the lowest: compounds 3, 2 and 1 (each within the scatter of the next, the first and the last beyond it).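

In this assay, for the compounds shown here, the cyano group on an aromatic carbon, para to a large group, offers the only look so far at a change on this ring, and it gives a 1.9-fold lower number from compound 2 to compound 3 (0.29 log units; within the scatter); on its own, this change therefore does not separate the two compounds. Going by these compounds alone, the exchange of the whole group on the ring nitrogen now reads differently with the cyano group in place: it gives a 2.1-fold lower number from compound 1 to compound 3 (0.32 log units; beyond the scatter), the only step here beyond the scatter, though only a modest one, whereas the same exchange with plain phenylcarbamoyl gave a 1.1-fold lower number from compound 1 to compound 2 (0.03 log units; within the scatter). No measured evidence accompanies these numbers that could account for either step.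

The compounds shown leave open whether the cyano group matters in particular or whether other groups at this carbon, such as fluorine, methoxy or a carboxylic acid, would give similar numbers. They also leave open whether a (4-cyanophenyl) group on the sulfonyl side, in place of the piperidine ring of compound 1, would give a similar number.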